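Swapping Methoxy for Fluoro: A Forecast for Compound 3

This account rests on a few compounds, and the source may have more. Where it says the series, first, only, none or still open, it means among the compounds named here.

Of the compounds shown here, two sharing one core have been measured. Compound 1 `Nc1ccccc1NC(=O)c1ccc(CSC(=S)N2CCN(c3ccccc3)CC2)cc1` carries hydrogen on the aromatic carbon in question, and in a functional assay on MGC-803 cells (Homo sapiens) for antiproliferative activity, read by CCK-8 assay, with a stated time of 72 h, tested at 8 uM (a higher number here means a stronger effect of the compound at the concentration tested, a lower number a weaker effect), compound 1 gives 87.4%. Compound 2 `COc1ccc(N2CCN(C(=S)SCc3ccc(C(=O)Nc4ccccc4N)cc3)CC2)cc1` carries methoxy there, and in this assay compound 2 gives 22.9%, the lowest of the two numbers. For the measured compounds named here, the single step between them, a number 64.5 percentage points lower from compound 1 to compound 2 (beyond the scatter), is the only measured step that bears on the new compound.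

Compound 3 `Nc1ccccc1NC(=O)c1ccc(CSC(=S)N2CCN(c3ccc(F)cc3)CC2)cc1` differs from compound 2 by fluoro in place of methoxy on an aromatic carbon. Going by the values given here, no measured pair shows fluoro in this place, so the forecast rests on the fact that hydrogen at this carbon went with a much higher number than methoxy did. Since fluoro is closer in size to hydrogen than methoxy is, compound 3 is expected to recover part of that loss, estimated as a number 37.1 percentage points higher from compound 2 to compound 3 (beyond the scatter), an increase beyond the scatter but not necessarily back to the level of compound 1. In this assay compound 3 is therefore estimated at 60%, with a plausible range from 25% to 88%.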

Compound 3, a percentage reported as inhibition, at one concentration (the size of the read-out at that concentration, not a potency): 48.7%
For compound 3 the middle estimate is 11.3 percentage points above the measured one; the range from low to high includes it.
By their numbers in this assay, from the lowest: compound 2; then compound 3; then compound 1.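

The new compound shows that the drop at this carbon, para to a large group, is not peculiar to methoxy: in this assay fluoro also goes with a fall from hydrogen, a number 38.7 percentage points lower from compound 1 to compound 3 (beyond the scatter) and thus beyond the scatter. The fall is nevertheless only partial, since exchanging methoxy for fluoro gives a number 25.8 percentage points higher from compound 2 to compound 3 (beyond the scatter) and places the 4-fluorophenyl compound in an intermediate position rather than at either end of the series. Across these three compounds alone, the number falls as the group at this carbon goes from hydrogen to fluoro, with its single heavy atom, and then to methoxy, with its two, although nothing given here explains that order.

Three compounds cannot show whether heavy-atom count is what orders these numbers, and a chlorine atom, a methyl group or an amine at the same carbon would test that order directly. Also open, from the compounds shown here alone, is whether fluoro and methoxy would give the same order at another carbon of this ring, and whether the order would hold at other concentrations, as each number here comes from a single concentration.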